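Notes on a cell-based inhibition series

The compounds below may be only part of what the source reports. "The series", "measured", "known", "first", "only" and "open" are said of these compounds alone.

Of the compounds shown here, three of this set have so far been measured in a functional assay on L02 cells (Homo sapiens) for inhibition, read by Griess assay, with stated times of 1 h and 24 h; a lower number here means a stronger inhibitor, a higher number a weaker inhibitor. Compound 1 `CCCc1nn(C)c2c(NC3CC3)nc(CCc3cccnc3)nc12` gives 564000 nM in this assay. Compound 2 `COc1cccc(CNc2nc(/C=C/c3ccccc3)nc3ccsc23)c1` returns only a limit of this assay, > 1000000 nM. Compound 3 `COc1cc(/C=C/c2nc(N3CCN(C)CC3)c3sccc3n2)cc(OC)c1OC` likewise returns only a limit of this assay, > 1000000 nM. Within the data shown here, compound 3 thus sits at the boundary of what this assay reports, together with compound 2, the only numeric value in the set being that of compound 1; the boundary in question is the limit of > 1000000 nM in this assay, at which 2 of the 3 values shown sit. Among the measured compounds shown here, no pair of measured compounds differs in a single place, so no measured step is available for this assay.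

Compound 4 `COc1cc(/C=C/c2nc(N(C)c3ccccc3)c3sccc3n2)cc(OC)c1OC` has not yet been measured in this assay. It differs from compound 3 in one place: methyl(phenyl)amino in place of 4-methylpiperazin-1-yl on an aromatic carbon. For the measured compounds named here, with no measured step to lean on and two of three values at the limit, there is no basis for expecting a move beyond the usual scatter in this assay, and a limit is the most likely outcome once more. The expected value for compound 4 is 1000000 nM, within 300000 nM to 3000000 nM. The step expected is a number no higher from compound 3 to compound 4 (the limit leaves the size open). The measured result for compound 4 follows.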

Compound 4, half-maximal inhibitory concentration: 767000 nM
Estimate against measurement, compound 4: 1.3-fold (0.12 log units) above; low and high end bracket the measured number.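

Among these compounds, the first measured step falls at this position, on an aromatic carbon next to the ring nitrogen: in this assay, methyl(phenyl)amino in place of 4-methylpiperazin-1-yl gives an at least 1.3-fold lower number from compound 3 to compound 4 (0.11 log units; that floor lies within the scatter). Compound 4 thus carries a number where compound 3 has only a limit, which shows that this place can take a carbon-only aromatic ring and still give a reading inside the reported range, although the floor of the step does not support a claim of real gain. The true size of the step stays unknown because compound 3 is held at a limit of the assay: the limit of > 1000000 nM in this assay, at which 2 of the 4 values shown sit.

The compounds shown do not separate the entering aromatic ring from the loss of the second nitrogen of the leaving group, as the two change together in this one step. From the compounds shown here alone, how a morpholin-4-yl or a plain dimethylamino group at this place would read in this assay, and whether any such group would move the number beyond the scatter from compound 4, remains open.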